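Phenyl for pyridinyl at the sulfur-bearing chain carbon

The source may report more compounds than this note shows. Statements on the series, on what has been measured and on what is new or still open speak of the compounds shown alone.

Compound 1 `CC(Sc1nc2nn(CC3COC3)cc2c(=O)n1-c1ccccc1)c1ccccc1` gives 80 nM in an assay on isolated protein for inhibition of retinal dehydrogenase 2 (Homo sapiens); a lower number here means a stronger inhibitor, a higher number a weaker inhibitor. Compound 2 `CC(Sc1nc2nn(C3COC3)cc2c(=O)n1-c1ccccc1)c1cccnc1` gives 58 nM in this assay, the lowest of the two numbers, with compound 1 as its nearest neighbour within the scatter. Compound 3 `CC(Sc1nc2nn(C3COC3)cc2c(=O)n1-c1ccccc1)c1ccccc1` differs from compound 2 by one change: phenyl in place of pyridin-3-yl on a saturated chain carbon bound to a saturated chain carbon and a sulfur. For the measured compounds named here, no measured pair shows this change alone, so the step is expected to be small, in no particular direction, and not beyond the scatter. Compound 3 is therefore expected to give 70 nM in this assay, between 30 nM and 170 nM, a step of a 1.2-fold higher number from compound 2 to compound 3 (0.08 log units; within the scatter).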

Compound 3, half-maximal inhibitory concentration: 65 nM
For compound 3 the middle estimate is 1.1-fold (0.03 log units) above the measured one, and the stated range covers the measured number.
By their numbers in this assay, from the lowest: compounds 2, 3 and 1 (each within the scatter of the next).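

In this assay phenyl in place of pyridin-3-yl on a saturated chain carbon bound to a saturated chain carbon and a sulfur gives a 1.1-fold higher number from compound 2 to compound 3 (0.05 log units; within the scatter) and so shows that, with oxetan-3-yl held fixed, this exchange alone stays within the scatter. Oxetan-3-yl in place of (oxetan-3-yl)methyl on an aromatic nitrogen gives a 1.2-fold lower number from compound 1 to compound 3 (0.09 log units; within the scatter) and shows the same for this second change with 1-phenylethyl held fixed.

Going by these compounds, whether an amine or a carboxylic acid on the phenyl ring, or a longer chain on the aromatic nitrogen, would move the number remains open. Nothing at hand accounts for either step.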